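The source may hold more compounds than are shown below. What is called first, only, known or untested is meant among the compounds shown, and "the series" means these compounds.

Working notes on the series.

Going by the values given here, compound 2 `COc1cccc2c1c(NS(=O)(=O)c1ccc(Cl)s1)nn2Cc1cccc(CNC(=O)C(C)(C)N)c1` gives 15.9 nM in a functional assay on CHO cells for antagonist activity at C-C chemokine receptor type 4 (Homo sapiens), read by GTPgammaS binding (on this read-out higher numbers stand for weaker inhibition and lower numbers for stronger inhibition), the lower of the two numbers measured so far; compound 1 `COc1cccc2c1c(NS(=O)(=O)c1ccc(Cl)s1)nn2Cc1cccc(CNC(=O)C2CCO2)c1` gives 31.6 nM in this assay, and the change of a 2.0-fold lower number from compound 1 to compound 2 (0.30 log units; within the scatter) stays within the scatter, so the two stand level.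

Compound 3 `COc1cccc2c1c(NS(=O)(=O)c1ccc(Cl)s1)nn2Cc1cccc(CNC2COC2)c1` differs from compound 2 by oxetan-3-yl in place of (1-amino-1-methylethyl)carbonyl on an amine nitrogen. Among the compounds with values here, no measured step touches the amide itself; the only known step, a 2.0-fold lower number from compound 1 to compound 2 (0.30 log units; within the scatter), swaps substituents on the carbonyl and moves little. The number for compound 3 is therefore expected to change by a 2.5-fold higher number from compound 2 to compound 3 (0.40 log units; beyond the scatter), with a wide range, toward somewhat weaker inhibition. Compound 3 is estimated at 40 nM in this assay, between 10 nM and 160 nM.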

Compound 3, half-maximal inhibitory concentration in the C-C chemokine receptor type 4 assay: 251 nM
Estimate against measurement, compound 3: 6.3-fold (0.80 log units) below; measured number above the stated range.
By their numbers in the C-C chemokine receptor type 4 assay, from the lowest: compounds 2 and 1 (each within the scatter of the next); then compound 3.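

In the C-C chemokine receptor type 4 assay, swapping groups on the carbonyl moved little, but with oxetan-3-yl in place of the whole acyl group on this amine nitrogen compound 3 gives 251 nM: the steps read a 16-fold higher number from compound 2 to compound 3 (1.20 log units; beyond the scatter) and a 7.9-fold higher number from compound 1 to compound 3 (0.90 log units; beyond the scatter). Both amides, compound 1 and compound 2, thus stand apart from compound 3 at this position. In a physicochemical assay for solubility, read by chemiluminescence, measured as kinetic solubility (on this read-out higher numbers stand for higher solubility and lower numbers for lower solubility), compound 2 gives >= 180 ug/mL, which is a limit of the assay. In the physicochemical assay compound 3 gives 122 ug/mL, so the step reads only as a floor: an at least 1.4-fold lower number from compound 2 to compound 3 (0.16 log units; that floor lies within the scatter).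

An acetyl or a simple methyl on the same amine nitrogen would separate loss of the carbonyl from entry of the oxetane ring. Nothing measured here accounts for the size of the step.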